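The source may hold more compounds than are shown below. What is called first, only, known or untested is meant among the compounds shown, and "the series" means these compounds.

Values in a functional assay on MDA-MB-231 cells (Homo sapiens) for antiproliferative activity, read by MTT assay; a higher number here means a weaker inhibitor, a lower number a stronger inhibitor
- compound 1 `CCCC/C=C\CCCCCCCCCc1cc(=O)c2c(O)cc(O)c(C)c2o1` gives 6790 nM
- compound 2 `CC/C=C\C/C=C\C/C=C\CCCCCCCc1cc(=O)c2c(O)cc(O)cc2o1` gives 6790 nM

Compound 2 stands level with compound 1 at the digits shown, and the two values lie within the scatter of each other. Going by the values given here, these two values are the only measurements so far, and no measured step yet isolates a single change.

Compound 3 `CCCC/C=C\CCCCCCCCCc1cc(=O)c2c(O)cc(O)cc2o1` is the next to be measured. It is reached from compound 2 by the change (a group of 8 heavy atoms (8 carbon; no ring) in place of a group of 10 heavy atoms (10 carbon; no ring), on a saturated chain carbon, seven bonds along the chain from an aromatic carbon). The oct-3-en-1-yl group replaces the larger group on a saturated chain carbon, seven bonds along the chain from an aromatic carbon.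

With compound 1 at 6790 nM and compound 2 at 6790 nM, no step beyond the scatter is expected in this assay. The expected change is a 1.0-fold higher number from compound 2 to compound 3 (0.00 log units; within the scatter). For compound 3 the estimated value is 6800 nM, with an expected range of 3000 nM to 15000 nM.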

Compound 3, half-maximal inhibitory concentration: 6790 nM
Compound 3: the middle estimate sits 1.0-fold (0.00 log units) above what was measured, within the range that was stated.
By their numbers in this assay, from the lowest: compounds 1, 2 and 3 (each within the scatter of the next).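

In this assay, putting oct-3-en-1-yl in place of the larger group with 3 double bonds, on a saturated chain carbon, seven bonds along the chain from an aromatic carbon, gives no change at the digits printed from compound 2 to compound 3 (within the scatter), so a change in chain size and double-bond count together leaves the value unmoved at this position. Going by these compounds alone, the first single change on the shared core, hydrogen in place of methyl on an aromatic carbon, gives no change at the digits printed from compound 1 to compound 3 (within the scatter), so this methyl also shows no effect beyond the scatter. No supporting data accompany these results to account for them.

The chain step alters size and double-bond count at once, so the contribution of each cannot be separated. On these data alone, whether a much longer chain, a chain ending in a carboxylic acid, or an amine on that aromatic carbon would shift the value remains open.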